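This account rests on a few compounds, and the source may have more. Where it says the series, first, only, none or still open, it means among the compounds named here.

Going by the values given here, in a functional assay on KG-1 cells (Homo sapiens) for cytotoxicity, read by luminescence and CellTiter-Glo, with a stated time of 3 days (on this read-out higher numbers stand for weaker inhibition and lower numbers for stronger inhibition), compound 3 (`N#Cc1ccc(NC(=O)c2ccccc2O)cc1`) gives 5370 nM as the highest number of the three measured so far. The numbers are lower for compound 1 (`Cc1ccc(C(=O)Nc2ccc(C#N)cc2)c(O)c1`) at 2560 nM and for compound 2 (`N#Cc1ccc(NC(=O)c2ccc(Br)cc2O)cc1Cl`) at 960 nM as the lowest of the three.

Compound 4 (`N#Cc1ccc(NC(=O)c2ccc(Br)cc2O)cc1`) is compound 3 with one change (bromo in place of hydrogen on an aromatic carbon), namely bromo in place of hydrogen on an aromatic carbon. Among the compounds with values here, the one measured step that bears on it is modest (a 2.1-fold higher number from compound 1 to compound 3 (0.32 log units; beyond the scatter)). There, a methyl group on that same carbon gives way to hydrogen, so a group at this place went with a lower number in this single pair. Compound 2 also carries the bromo, together with a chloro group that compound 4 lacks, so its value cannot show what bromo alone does.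

A modest step towards a lower number therefore seems likely. In this assay the expected step is a 2.7-fold lower number from compound 3 to compound 4 (0.43 log units; beyond the scatter) and points towards stronger inhibition. For compound 4 the estimated value is 2000 nM (expected range from 900 nM to 4500 nM).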

Compound 4, half-maximal inhibitory concentration: 1450 nM
Beside the measured number, compound 4's estimate is 1.4-fold (0.14 log units) above it, and the stated range covers the measured number.
By their numbers in this assay, from the lowest: compounds 2, 4 and 1 (each within the scatter of the next, the first and the last beyond it); then compound 3.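

With bromo at this place, meta to a hydroxy group and para to a large group, this assay shows a 3.7-fold lower number from compound 3 to compound 4 (0.57 log units; beyond the scatter). Hydrogen now stands apart from two different groups on this carbon, because methyl and bromo both go with lower numbers, while those two groups cannot be told apart (a 1.8-fold lower number from compound 1 to compound 4 (0.25 log units; within the scatter)). The extra chloro group of compound 2 also makes no clear difference here (a 1.5-fold higher number from compound 2 to compound 4 (0.18 log units; within the scatter)).

Nothing shown explains why a group on this carbon goes with a lower number. From the compounds shown here alone, whether an amine, a carboxylic acid or a longer chain on this carbon would also go with a lower number than hydrogen remains open.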